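Moving the acid closer to the ring in a urea series

The compounds below may be only part of what the source reports. "The series", "measured", "known", "first", "only" and "open" are said of these compounds alone.

Measured compounds:
compound 1, `CC(C)CC1(O)CCN(C(=O)Nc2cc(Oc3ccc(C(=O)O)cc3)cc(Oc3ccc(F)cc3F)c2)CC1`, 18.5 nM
compound 2, `CC(C)CC1(O)CCN(C(=O)Nc2cc(Oc3ccc(F)cc3)cc(Oc3ccc(CC(=O)O)cc3)c2)CC1`, 237 nM
compound 3, `CC(C)CC1(O)CCN(C(=O)Nc2cc(Oc3ccc(C(=O)O)cc3)cc(Oc3ccc(F)c(F)c3)c2)CC1`, 22.2 nM

In an ADME assay on the whole organism for pharmacokinetics, with Rattus norvegicus as the target, at a dose of 1 mg/kg by the oral route (a lower number here means less compound in the circulation, a higher number more compound in the circulation at the dose given), compound 2 gives the highest of the three numbers; compound 3 sits below it in the sense that its value is far lower, and compound 1 lower still, both gaps beyond the scatter. Compound 4, `CC(C)CC1(O)CCN(C(=O)Nc2cc(Oc3ccc(F)cc3)cc(Oc3ccc(C(=O)O)cc3F)c2)CC1`, has not been measured. It differs from compound 2 in one place: 4-carboxy-2-fluorophenyl in place of 4-(carboxymethyl)phenyl on an oxygen on an aromatic ring. Among the compounds with values here, no measured step matches this change exactly. Within the data shown here, the only measured step, a 1.2-fold higher number from compound 1 to compound 3 (0.08 log units; within the scatter), concerns the other ring and is within the scatter, so it says little here. What does bear on it is that compound 1 and compound 3, which carry a carboxy group rather than a carboxymethyl group on that ring, both give far lower numbers than compound 2. Compound 4 is therefore expected to move in the same direction, with a lower number, a step of about a 6.8-fold lower number from compound 2 to compound 4 (0.83 log units; beyond the scatter). The estimate for compound 4 in this assay is 35 nM, with a range from 12 nM to 110 nM.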

Compound 4, maximal plasma concentration: 27.8 nM
The estimate for compound 4 lay 1.3-fold (0.10 log units) above the measured number, within the range that was stated.
By their numbers in this assay, from the lowest: compounds 1, 3 and 4 (each within the scatter of the next); then compound 2.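

In this assay, putting 4-carboxy-2-fluorophenyl in place of 4-(carboxymethyl)phenyl on this oxygen gives an 8.5-fold lower number from compound 2 to compound 4 (0.93 log units; beyond the scatter) and so clearly lowers the amount of compound in the circulation at this dose. Within the data shown here, this is the first comparison here in which only this group changes, so the gap can be tied to this one place rather than to differences spread over both rings. Nothing measured here explains why the number falls.

The change also does two things at once, replacing carboxymethyl with carboxy and adding a fluorine, so the step cannot say which of them matters. A 4-(carboxymethyl)-2-fluorophenyl group on the same oxygen would help separate the two, while the effect of a longer chain, as in 4-(2-carboxyethyl)phenyl, remains an open question.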